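Dropping the aryl group: compound 3 foreseen from compound 2

The source may report more compounds than this note shows. Statements on the series, on what has been measured and on what is new or still open speak of the compounds shown alone.

Compound 2 `OC(CCn1nc2c(Br)c(Br)c(Br)c(Br)c2n1)c1ccc(Br)cc1` stands lowest of the two numbers in a functional assay on MCF7 cells (Homo sapiens) for antiproliferative activity, read by MTT assay, with a stated time of 24 h, tested at 100 uM (on this read-out lower numbers stand for a stronger effect and higher numbers for a weaker effect at the one concentration tested), where compound 2 gives 0%; its nearest neighbour is compound 1 `COc1cccc(C(O)CCn2nc3c(Br)c(Br)c(Br)c(Br)c3n2)c1`, which in this assay gives 16%. Compound 3 `CC(O)CCn1nc2c(Br)c(Br)c(Br)c(Br)c2n1` differs from compound 2 by methyl in place of 4-bromophenyl on a saturated chain carbon bound to an oxygen on a saturated carbon and a saturated chain carbon. Going by the values given here, only one measured step bears on this change: a number 16 percentage points lower from compound 1 to compound 2 (beyond the scatter), a swap of one aryl group for another, whereas the move to compound 3 removes the aryl group outright. With compound 2 already at the floor of the read-out, compound 3 is expected to rise, an estimated step of a number 20 percentage points higher from compound 2 to compound 3 (beyond the scatter), so compound 3 is estimated at 20%, with a range from 0% to 55%.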

Compound 3, a percentage reported as activity, at one concentration (the size of the read-out at that concentration, not a potency): 57%
The estimate for compound 3 lay 37 percentage points below the measured number, and the stated range ends below it.
By their numbers in this assay, from the lowest: compound 2; then compound 1; then compound 3.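

In this assay the presence of an aryl group on this carbon counts for more than which aryl group it is: methyl in its place gives a number 57 percentage points higher from compound 2 to compound 3 (beyond the scatter) and a number 41 percentage points higher from compound 1 to compound 3 (beyond the scatter), both large, against the modest a number 16 percentage points lower from compound 1 to compound 2 (beyond the scatter) for the swap of one aryl group for the other. Since lower numbers stand for a stronger effect, compound 3 is the weakest of the three at the one concentration tested. Nothing at hand explains this difference. As far as these compounds go, whether a cyclohexyl group or a longer chain on this carbon would give a number near those of the aryl compounds or near that of compound 3 remains open.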